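Pyridin-3-yl in place of 3-fluorophenyl in compound 2

A few compounds are considered here, and "the series" means these few. Any claim that something is new, unique, unknown or untested is made for them only; others in the source may bear on it.

In an ADME assay on HEK293 cells (Homo sapiens) for cytotoxicity, with a stated time of 72 h (a lower number here means that less compound is needed, a higher number that more compound is needed for the effect), compound 2 `Cc1cc(NC(=O)Nc2cccc(F)c2)c2ccccc2n1` gives > 25000 nM, which is a limit and not a number. Compound 1 `Cc1ccc(NC(=O)Nc2cc(C)nc3ccccc23)cc1` gives > 25000 nM, also a limit. Going by the values given here, compound 3 `COC(=O)c1cccc(NC(=O)Nc2cc(C)nc3ccccc23)c1` gives 26000 nM, the only true number so far. The picture is thus (the limit of > 25000 nM in this assay, at which 2 of the 3 values shown sit).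

Compound 4 `Cc1cc(NC(=O)Nc2cccnc2)c2ccccc2n1` differs from compound 2 by pyridin-3-yl in place of 3-fluorophenyl on an amide-type nitrogen.

Among the compounds with values here, two measured steps bear on this: a step that the two limits leave unreadable from compound 1 to compound 2 and a step that the limit leaves unreadable from compound 2 to compound 3. Neither has a readable size. With compound 3 at 26000 nM, no clear step is expected in this assay. The estimated move is a step that the limit leaves unreadable from compound 2 to compound 4, with none expected beyond the scatter. For compound 4 the expected value is 30000 nM, within an estimated range of 15000 nM to 60000 nM.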

Compound 4, half-maximal effective concentration: > 25000 nM
Compound 4 was reported as a limit (the forecaster's own chance of this, stated with the estimate: 75%); the middle value lies beyond the limit too.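

Compound 1, compound 2 and compound 4 are all reported only as limits, so no step among them can be read: the limit of > 25000 nM in this assay, at which 3 of the 4 values shown sit.

The compounds shown leave open how much compound is actually needed for the effect in this assay with pyridin-3-yl, 3-fluorophenyl or 4-methylphenyl on the amide-type nitrogen.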